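Notes on a prostaglandin D2 receptor 2 binding series

The source may hold more compounds than are shown below. What is called first, only, known or untested is meant among the compounds shown, and "the series" means these compounds.

Compound 1 `O=C(O)Cc1sc(C(c2ccccc2)c2ccc(F)cc2)nc1-c1ccc(Cl)cc1` gives 17 nM in an in vitro assay on HEK385-7 cells for displacement of a labelled ligand from prostaglandin D2 receptor 2 (Homo sapiens); a lower number here means a stronger inhibitor, a higher number a weaker inhibitor. Compound 2 `O=C(O)Cc1sc(C(c2ccc(F)cc2)c2ccc(F)cc2)nc1-c1ccc(Cl)cc1` gives 9.7 nM, and compound 3 `COc1ccc(C(c2ccccc2)c2nc(-c3ccc(Cl)cc3)c(CC(=O)O)s2)cc1` gives 8.4 nM, so the number for compound 2 lies within the scatter of both compound 1 and compound 3. The step of a 1.8-fold lower number from compound 1 to compound 2 (0.24 log units; within the scatter) and the step of a 2.0-fold lower number from compound 1 to compound 3 (0.31 log units; beyond the scatter) both concern a different part of the shared core. Compound 4 `O=C(O)Cc1sc(C(c2ccc(F)cc2)c2ccc(F)cc2)nc1-c1cc(F)cc(F)c1` differs from compound 2 by 3,5-difluorophenyl in place of 4-chlorophenyl on an aromatic carbon. Neither measured step touches this position, so the measured steps offer no direct guide. The expected step of a 1.2-fold higher number from compound 2 to compound 4 (0.09 log units; within the scatter) is therefore one within the scatter. Compound 4 is estimated at 12 nM, with a range from 4 nM to 36 nM.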

Compound 4, half-maximal inhibitory concentration: 35 nM
For compound 4 the middle estimate is 2.9-fold (0.46 log units) below the measured one, and the stated range covers the measured number.
By their numbers in this assay, from the lowest: compounds 3, 2 and 1 (each within the scatter of the next, the first and the last beyond it); then compound 4.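

Exchanging 4-chlorophenyl for 3,5-difluorophenyl on the aromatic carbon next to the ring nitrogen gives a 3.6-fold higher number from compound 2 to compound 4 (0.56 log units; beyond the scatter). Among the compounds shown here, this position, untouched by the earlier steps, is therefore one where a change of aryl group can move the number beyond the scatter. No supporting measurement bears on the reason for this step.

Since the change alters the substitution in two respects at once, the compounds shown leave open whether removing the 4-chloro group or adding the 3,5-difluoro pattern carries the step. Also open, going by these compounds, is how a 4-bromophenyl or a 3-chlorophenyl group would read at this position.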